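A few compounds are considered here, and "the series" means these few. Any claim that something is new, unique, unknown or untested is made for them only; others in the source may bear on it.

In a functional assay on HepG2 cells (Homo sapiens) for inhibition, read by MTT assay, with a stated time of 72 h (on this read-out lower numbers stand for stronger inhibition and higher numbers for weaker inhibition), the measured compounds are these:

- Compound 1 `Cc1ccc(CN2CCc3ncn(COCc4ccccc4)c3/C(=C/c3ccccc3)C2=O)cc1` gives 44700 nM
- Compound 2 `Cc1cccc(CN2CCc3ncn(COCc4ccccc4)c3/C(=C/c3ccccc3)C2=O)c1` gives 34300 nM
- Compound 3 `O=C1/C(=C\c2ccccc2)c2c(ncn2COCc2ccccc2)CCN1Cc1ccc(-c2ccccc2)cc1` gives 72500 nM

Among these three, compound 3 at 72500 nM is set apart from only one neighbour. The numbers show a 2.1-fold higher number from compound 2 to compound 3 (0.33 log units; beyond the scatter) and also a 1.6-fold higher number from compound 1 to compound 3 (0.21 log units; within the scatter) so only the first of these gaps clears the scatter.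

The next step leads to compound 4 (`Cc1ccccc1CN1CCc2ncn(COCc3ccccc3)c2/C(=C/c2ccccc2)C1=O`) which has not yet been measured. Here 2-methylphenyl takes the place of 4-phenylphenyl, and the counted difference is 2-methylphenyl in place of 4-phenylphenyl on a saturated chain carbon bound to an amide-type nitrogen in a ring for this exchange.

Two kinds of measured step bear on it. The steps into compound 3 from compound 1 and compound 2 are the same kind of exchange run the other way, and they are small. The shift of the methyl group shows a 1.3-fold lower number from compound 1 to compound 2 (0.12 log units; within the scatter) so moving it has not yet produced a change beyond the scatter. Within the data shown here, no measured compound carries 2-methylphenyl itself. A small step toward lower numbers is therefore expected, and it may not clear the scatter. The expected change is a 1.8-fold lower number from compound 3 to compound 4 (0.25 log units; within the scatter) in this assay on this reasoning. For compound 4 the estimated value is 41000 nM (expected range 22000 nM to 75000 nM).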

Compound 4, half-maximal inhibitory concentration: 53300 nM
Estimate against measurement, compound 4: 1.3-fold (0.11 log units) below, and the stated range covers the measured number.
By their numbers in this assay, from the lowest: compounds 2, 1, 4 and 3 (each within the scatter of the next, the first and the last beyond it).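

In this assay, 2-methylphenyl completes the set of methylphenyl groups at this position, and neither a 1.6-fold higher number from compound 2 to compound 4 (0.19 log units; within the scatter) nor a 1.2-fold higher number from compound 1 to compound 4 (0.08 log units; within the scatter) sets it apart from the other two placements of the methyl group. The new result also bears on the size of the group: going from 4-phenylphenyl, with 12 heavy atoms and 2 six-membered aromatic rings, to 2-methylphenyl, with 7 heavy atoms and one such ring, gives a 1.4-fold lower number from compound 3 to compound 4 (0.13 log units; within the scatter) and so does not separate the two compounds, even though this exchange removes a whole aromatic ring. Thus a 2.1-fold higher number from compound 2 to compound 3 (0.33 log units; beyond the scatter) remains the only step in this small series beyond the scatter, and no information is available to explain why these changes at this position have so little effect.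

As far as these compounds go, all four groups at this position are all-carbon aromatic groups with no net charge, so it remains open whether an amine or a carboxylic acid on the phenyl ring would move the number further. From the compounds shown here alone, it is equally open whether a longer chain in place of the single saturated carbon would do so, and whether any change here could give a number well below those of this series.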